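A few compounds are considered here, and "the series" means these few. Any claim that something is new, unique, unknown or untested is made for them only; others in the source may bear on it.

Compound 2 `CCOC(=O)C1=C(C)N/C(=C/c2cc(C)n(-c3ccc(F)cc3F)c2C)C1=O` stands with compound 3 `CCOC(=O)C1=C(C)N/C(=C/c2cc(C)n(-c3ccc(OC)cc3)c2C)C1=O` at the low end of the three measurements in a physicochemical assay for lipophilicity, read by HPLC, at pH 7.4; a higher number here means a more lipophilic compound, a lower number a more polar compound: compound 2 gives 3, compound 3 gives 3, and compound 1 `CCOC(=O)C1=C(C)N/C(=C/c2cc(C)n(-c3ccc(CN(C)C)cc3)c2C)C1=O` gives 8.3. The step of no change at the digits printed from compound 2 to compound 3 (within the scatter) is within the scatter, whereas a number 5.30 log units lower from compound 1 to compound 2 (beyond the scatter) and a number 5.30 log units lower from compound 1 to compound 3 (beyond the scatter) are both large. Compound 4 `CCOC(=O)C1=C(C)N/C(=C/c2cc(C)n(-c3ccncc3)c2C)C1=O` differs from compound 2 by pyridin-4-yl in place of 2,4-difluorophenyl on an aromatic nitrogen. Two measured steps swap the group on the aromatic nitrogen, one large and one within the scatter; none of them introduces pyridin-4-yl, so the bearing of these steps is indirect. A moderate downward step a number 1.00 log units lower from compound 2 to compound 4 (beyond the scatter) is expected, smaller than either large step seen. Compound 4 is estimated at 2, within 1 to 3.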

Compound 4, distribution coefficient: 3.2
For compound 4 the middle estimate is 1.20 log units below the measured one; measured number outside the range, above it.
By their numbers in this assay, from the lowest: compounds 2, 3 and 4 (each within the scatter of the next); then compound 1.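

In this assay, pyridin-4-yl on the aromatic nitrogen does not set compound 4 apart from the two fluorine- or methoxy-bearing aryl compounds: a number 0.20 log units higher from compound 2 to compound 4 (within the scatter), and a number 0.20 log units higher from compound 3 to compound 4 (within the scatter). Within these compounds, the entering ring nitrogen and its hydrogen-bond acceptor leave the number within the scatter, whereas a number 5.10 log units lower from compound 1 to compound 4 (beyond the scatter), leaving compound 1 alone at the high end. Nothing available accounts for this pattern. Open, going by these compounds, is whether another amine on the phenyl ring, such as morpholinomethyl, would give a number like that of compound 1. Also open, on these data alone, is where a carboxylic acid there would fall.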